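The source may report more compounds than this note shows. Statements on the series, on what has been measured and on what is new or still open speak of the compounds shown alone.

Measured so far in a functional assay on MDA-MB-435 cells (Homo sapiens) for cytotoxicity, read by MTT assay, with a stated time of 72 h; a lower number here means a stronger inhibitor, a higher number a weaker inhibitor:
Compound 1 `CN(C)c1ccc(/C=N/Nc2nc3ccccc3s2)cc1`: > 16800 nM (a limit)
Compound 2 `Brc1ccc(/C=N/Nc2nc3ccccc3s2)cc1`: > 15000 nM (a limit)

Compound 2 stands only at a limit, > 15000 nM. Among the measured compounds shown here, the one other value, that of compound 1, is also a limit, so no compound yet has a readable number.

Compound 3 `Oc1ccc(/C=N/Nc2nc3ccccc3s2)cc1` keeps the shared core and has hydroxy in place of bromo on an aromatic carbon, para to a large group (hydroxy in place of bromo on an aromatic carbon). For the measured compounds named here, the one measured step that bears on this is bromo in place of dimethylamino on an aromatic carbon, a step that the two limits leave unreadable from compound 1 to compound 2. Neither end of that step gives a number, so it offers no size or direction to carry over. No step beyond the scatter is therefore expected in this assay, and compound 3 may well be reported as a limit again.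

Expressed as a step, the expectation is a step that the limit leaves unreadable from compound 2 to compound 3. For compound 3 the estimated value is 16000 nM, with an expected range from 6000 nM to 25000 nM.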

Compound 3, half-maximal inhibitory concentration: > 18500 nM
Compound 3 ended at the assay's limit; the forecaster's own chance of this, stated with the estimate: 70%; middle value at least 1.1-fold (0.06 log units) from the limit.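

In this assay compound 3 gives > 18500 nM, which is a limit and not a number. Among the compounds shown here, compound 1, compound 2 and compound 3 all stand at limits, so no step among them can be read. The compounds shown leave open whether any of these groups on the aromatic carbon changes the value in this assay, and in which direction.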